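Thiophen-2-yl in place of pyridin-3-yl

This account rests on a few compounds, and the source may have more. Where it says the series, first, only, none or still open, it means among the compounds named here.

In an ADME assay on MT4 cells (Homo sapiens) for cytotoxicity, read by MTT assay (a higher number here means that more compound is tolerated, a lower number that less compound is tolerated), compound 1 `Cc1cccc(C)c1S(=O)(=O)c1c(C(N)=O)[nH]c2ccc(Cl)cc12` gives > 48900 nM, which is a limit and not a number. Compound 2 `Cc1cccc(C)c1S(=O)(=O)c1c(C(=O)NCc2ccncc2)[nH]c2ccc(Cl)cc12` gives > 55000 nM, likewise a limit. Among the compounds with values here, compound 3 `Cc1cc(C)cc(S(=O)(=O)c2c(C(=O)NC(C)c3cccnc3)[nH]c3ccc(Cl)cc23)c1` gives 54600 nM, the only actual number among the three values.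

Compound 4 `Cc1cc(C)cc(S(=O)(=O)c2c(C(=O)NC(C)c3cccs3)[nH]c3ccc(Cl)cc23)c1` has thiophen-2-yl in place of pyridin-3-yl on a saturated chain carbon bound to an amide-type nitrogen and a saturated chain carbon.

Within the data shown here, the only measured step is a step that the two limits leave unreadable from compound 1 to compound 2, with (pyridin-4-yl)methyl in place of hydrogen on an amide-type nitrogen. It is a different change, and its size cannot be read, so it gives no guide to the size or direction of this one. The working anchor is therefore compound 3 at 54600 nM, and no step beyond the scatter is expected in this assay. The estimated change is a 1.3-fold lower number from compound 3 to compound 4 (0.11 log units; within the scatter), which is expected to stay within the scatter. For compound 4 the estimate is 42000 nM, with an expected range of 14000 nM to 110000 nM.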

Compound 4, half-maximal cytotoxic concentration: 32300 nM
Estimate against measurement, compound 4: 1.3-fold (0.11 log units) above; the measured number falls inside the stated range.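

In this assay the change to thiophen-2-yl in place of pyridin-3-yl, on a saturated chain carbon bound to an amide-type nitrogen and a saturated chain carbon, gives a 1.7-fold lower number from compound 3 to compound 4 (0.23 log units; within the scatter). Within the data shown here, this is the only readable step so far, and it shows that a six-membered aromatic ring with a nitrogen and a five-membered aromatic ring with a sulfur can be exchanged at this place without a step beyond the scatter. Nothing measured here bears on a cause for this step.

The other step, from compound 1 to compound 2, joins two limits and cannot be read. This single pair leaves open whether a phenyl ring, a longer chain or a group carrying an amine or a carboxylic acid at this place would also stay within the scatter of compound 3.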